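This account rests on a few compounds, and the source may have more. Where it says the series, first, only, none or still open, it means among the compounds named here.

Working notes on the series. The shared core is that of compound 1 `CCOC(=O)CCCCCOc1cccc(CN(C(=O)c2ccc(-c3cccc(N(C)C)c3)cc2)C(C)C)c1`; compound 2 `CCOC(=O)CCCCCOc1cccc(CN(C(=O)c2ccc(-c3cccc(O)c3)cc2)C(C)C)c1` and compound 3 `CCOC(=O)CCCCCOc1cccc(CN(C(=O)c2ccc(-c3cc(F)cc(OC)c3)cc2)C(C)C)c1` vary only the aryl group attached to it. In an ADME assay on BJ cells (Homo sapiens) for cytotoxicity, read by CellTiter-Glo and resazurin assay, with a stated time of 72 h (a lower number here means that less compound is needed, a higher number that more compound is needed for the effect), compound 1 gives > 26000 nM, which is a limit of the assay and not a number. Compound 2 likewise reaches only the limit > 26000 nM in this assay. Compound 3 also stands at the limit > 26000 nM in this assay. All three values therefore sit at the limit of > 26000 nM in this assay, at which 3 of the 3 values shown sit, so the steps a step that the two limits leave unreadable from compound 1 to compound 2, a step that the two limits leave unreadable from compound 1 to compound 3 and a step that the two limits leave unreadable from compound 2 to compound 3 give no readable size.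

Compound 4 `CCOC(=O)CCCCCOc1cccc(CN(C(=O)c2ccc(-c3cccc([N+](=O)[O-])c3)cc2)C(C)C)c1` is not yet measured. It differs from compound 3 by 3-nitrophenyl in place of 3-fluoro-5-methoxyphenyl on an aromatic carbon. Among the compounds with values here, none of the measured steps bears on this change with a readable size; what the three values show is that every aryl variation so far has stayed at the limit in this assay. No step beyond the scatter is expected, and the step of a number no higher from compound 3 to compound 4 (the limit leaves the size open) is expected to be nil. Compound 4 is thus estimated at 26000 nM, in the range 10000 nM to 100000 nM, most likely reported again as a limit.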

Compound 4, half-maximal effective concentration: < 1.3 nM
Compound 4: a limit, no number; the forecaster's own chance of this, stated with the estimate: 85%; middle value at least 20000-fold (4.30 log units) from the limit.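

In this assay compound 4 gives < 1.3 nM, a limit of the assay and not a number. A change on this aromatic carbon, para to a large group, can therefore move the value very far: 3-nitrophenyl in place of 3-fluoro-5-methoxyphenyl gives an at least 20000-fold lower number from compound 3 to compound 4 (4.30 log units; beyond the scatter), nitro in place of hydroxy gives an at least 20000-fold lower number from compound 2 to compound 4 (4.30 log units; beyond the scatter), and nitro in place of dimethylamino gives an at least 20000-fold lower number from compound 1 to compound 4 (4.30 log units; beyond the scatter). The steps among the three earlier compounds cannot be read, so these are the first readable sizes for an aryl change in the series, and compound 4 alone stands at the lower limit: the limit of < 1.3 nM in this assay, at which 1 of the 4 values shown sits.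

The compounds shown leave open whether a nitrile or a trifluoromethyl group in place of the nitro would give a similar step. They also leave open the true size of the value of compound 4, and whether a carboxylic acid in place of the ester would keep it.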